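Propanoyl Capping of an Aminoselenazole Isothiocyanate

The source may hold more compounds than are shown below. What is called first, only, known or untested is meant among the compounds shown, and "the series" means these compounds.

Measured compounds:
- compound 1, `CC(=O)Nc1nc(CCl)c[se]1`: > 100000 nM
- compound 2, `Nc1nc(CN=C=S)c[se]1`: 21000 nM
- compound 3, `CC(C)(C)c1ccc(C(=O)Nc2nc(CN=C=S)cs2)cc1`: > 100000 nM

For the measured compounds named here, in a functional assay on L1210 cells (Mus musculus) for antiproliferative activity (on this read-out higher numbers stand for weaker inhibition and lower numbers for stronger inhibition), compound 2 gives 21000 nM, the only actual number among the three. Compound 1 reports only a limit, > 100000 nM. Compound 3 likewise reports only a limit, > 100000 nM. Compound 1 and compound 3 both sit at the limit of > 100000 nM in this assay, at which 2 of the 3 values shown sit.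

Compound 4, `CCC(=O)Nc1nc(CN=C=S)c[se]1`, carries propanoyl in place of hydrogen on a nitrogen on an aromatic ring relative to compound 2. Going by the values given here, no measured step covers this change. Still, a step toward weaker inhibition beyond the usual scatter is expected because compound 1 and compound 3, each acylated on that nitrogen, sit at the limit of > 100000 nM in this assay, at which 2 of the 3 values shown sit. The expected step of a 2.9-fold higher number from compound 2 to compound 4 (0.46 log units; beyond the scatter) points that way. Compound 4 is therefore estimated at 60000 nM, between 20000 nM and 200000 nM.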

Compound 4, half-maximal inhibitory concentration: 3500 nM
The estimate for compound 4 lay 17-fold (1.23 log units) above the measured number; the measured number lies below the stated range.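

In this assay, putting propanoyl in place of hydrogen on this nitrogen strengthens inhibition, with a 6.0-fold lower number from compound 2 to compound 4 (0.78 log units; beyond the scatter). So, in this pair, the hydrogen on that nitrogen is not needed for activity, and capping it can help. Compound 1 and compound 3 also carry acyl groups there, but each differs from compound 4 in other places as well, so their limits cannot be read as the effect of this change: the limit of > 100000 nM in this assay, at which 2 of the 4 values shown sit.

From the compounds shown here alone, whether a longer chain, such as butanoyl, would go further remains open. So does whether an amine at the end of the chain would keep this activity.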